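Cytotoxicity of three compounds, and a benzyl swap

A few compounds are considered here, and "the series" means these few. Any claim that something is new, unique, unknown or untested is made for them only; others in the source may bear on it.

Values so far in an ADME assay on C8166 cells (Homo sapiens) for cytotoxicity, read by MTT assay (on this read-out lower numbers stand for higher toxicity in this test and higher numbers for lower toxicity in this test), for the three measured compounds

Compound 1 `Cc1ccc(-n2cc(C(=O)O)c(=O)c3c(O)c(Cc4cccc(Cl)c4F)ccc32)cc1` gives 194000 nM
Compound 2 `Cc1ccc(-n2cc(C(=O)O)c(=O)c3c(O)c(Cc4cccc(Cl)c4F)ccc32)cc1C` gives 316000 nM
Compound 3 `O=C(O)c1cn(-c2ccc(Br)cc2)c2ccc(Cc3cccc(Cl)c3F)c(O)c2c1=O` gives 85000 nM

Of these three, compound 3 stands lowest, which makes it the most toxic to the cells in this small set. Compound 4 `O=C(O)c1cn(Cc2cccc(F)c2)c2ccc(Cc3cccc(Cl)c3F)c(O)c2c1=O` keeps the shared core but carries 3-fluorobenzyl in place of 4-bromophenyl on an aromatic nitrogen. The change in detail is 3-fluorobenzyl in place of 4-bromophenyl on an aromatic nitrogen and nothing else differs.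

Going by the values given here, three measured steps concern the group on that nitrogen. There is a 1.6-fold higher number from compound 1 to compound 2 (0.21 log units; within the scatter) when a methyl is added, then a 2.3-fold lower number from compound 1 to compound 3 (0.36 log units; beyond the scatter) and also a 3.7-fold lower number from compound 2 to compound 3 (0.57 log units; beyond the scatter) when bromo is present. Among the compounds with values here, none of these steps replaces a directly attached ring with a benzyl group, so the data hold no direct precedent for this swap.

Since compound 3 at 85000 nM is the only one of the three carrying bromo, losing that group may bring the number back toward those of compound 1 and compound 2. A modest rise is therefore expected in this assay with wide uncertainty. The estimated change is a 2.2-fold higher number from compound 3 to compound 4 (0.35 log units; beyond the scatter) in size. Compound 4 is estimated at 190000 nM within an expected range of 70000 nM to 450000 nM overall.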

Compound 4, half-maximal cytotoxic concentration: 69000 nM
For compound 4 the middle estimate is 2.8-fold (0.44 log units) above the measured one, outside the stated range (below it).
By their numbers in this assay, from the lowest: compounds 4 and 3 (each within the scatter of the next); then compounds 1 and 2 (each within the scatter of the next).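

Swapping the directly attached ring for a 3-fluorobenzyl group on the aromatic nitrogen gives a 1.2-fold lower number from compound 3 to compound 4 (0.09 log units; within the scatter), so these two groups cannot be told apart in this assay, and a benzyl group is tolerated here without any clear shift in the number. The comparisons with the methyl-bearing rings give a 2.8-fold lower number from compound 1 to compound 4 (0.45 log units; beyond the scatter) and a 4.6-fold lower number from compound 2 to compound 4 (0.66 log units; beyond the scatter), which shows that the low end of this small set is not tied to bromo: compound 4 carries no bromine, yet it sits with compound 3 and apart from compound 1 and compound 2. Nothing in the data shown explains why the numbers fall this way.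

Compound 4 brings in the benzyl form and the fluorine together, so the compounds shown cannot say which of the two goes with its number, and a plain benzyl group with no fluorine would separate them. On these data alone, a group of another kind on the same nitrogen, such as a short chain ending in an amine or a carboxylic acid, also remains open, as does whether the number would then leave this narrow range.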